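The compounds below may be only part of what the source reports. "The series", "measured", "known", "first", "only" and "open" are said of these compounds alone.

Measured compounds:
- compound 1, `C=C1C(=O)[C@]23C[C@@]1(O)CC[C@H]2c1ccc(OS(=O)(=O)c2ccc(C)cc2)c(C)c1[C@@H]3Cn1cc(-c2ccccn2)nn1`, 2830 nM
- compound 2, `C=C1C(=O)[C@]23C[C@@]1(O)CC[C@H]2c1ccc(OS(=O)(=O)c2ccc(C)cc2)c(C)c1[C@@H]3Cn1cc(-c2ccc(Br)cc2)nn1`, 4320 nM
- compound 3, `C=C1C[C@]23C[C@@]1(O)CC[C@@H]2c1cccc(C)c1[C@@H]3Cn1cc(-c2ccc(Br)cc2)nn1`, > 20000 nM

All three were tested in a functional assay on SMMC-7721 cells (Homo sapiens) for cytotoxicity, read by MTT assay, with a stated time of 4 days; a higher number here means a weaker inhibitor, a lower number a stronger inhibitor. In this assay compound 1 gives 2830 nM and compound 2 gives 4320 nM. For compound 3 the assay gives only a limit, > 20000 nM, and not a number.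

Compound 1 and compound 2 share one core and differ in a single place: pyridin-2-yl in place of 4-bromophenyl on an aromatic carbon. The step this change made is a 1.5-fold lower number from compound 2 to compound 1 (0.18 log units; within the scatter), so the two values are indistinguishable here. Compound 3 carries a different core from compound 2; the difference between the two cores is not broken down here.

Compound 4, `C=C1C[C@]23C[C@@]1(O)CC[C@@H]2c1cccc(C)c1[C@@H]3Cn1cc(-c2ccccn2)nn1`, has not yet been measured. It stands to compound 3 exactly as compound 1 stands to compound 2: pyridin-2-yl in place of 4-bromophenyl on an aromatic carbon. The surroundings of the change are described in the same words in both pairs, so this is the same change, made a second time on a different core.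

Compound 4 is expected to sit at or near the same limit as compound 3, because compound 3 already sits at the limit of > 20000 nM in this assay, at which 1 of the 3 values shown sits, and the same change between compound 2 and compound 1 gave a 1.5-fold lower number from compound 2 to compound 1 (0.18 log units; within the scatter). The step from compound 3 to compound 4 is therefore expected to be about a step that the limit leaves unreadable from compound 3 to compound 4. The estimated value for compound 4 in this assay is 25000 nM, with a plausible range from 10000 nM to 60000 nM.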

Compound 4, half-maximal inhibitory concentration: > 20000 nM
Compound 4 was reported as a limit; the forecaster's own chance of this, stated with the estimate: 75%; the middle value lies beyond the limit too.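

In this assay, compound 3 and compound 4 are each reported only as a limit and not as a number, so no step between them can be read: the limit of > 20000 nM in this assay, at which 2 of the 4 values shown sit.

The compounds shown leave open whether pyridin-2-yl in place of 4-bromophenyl changes the activity at all on the core shared by compound 3 and compound 4.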